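This account rests on a few compounds, and the source may have more. Where it says the series, first, only, none or still open, it means among the compounds named here.

Of the compounds shown here, three sharing one core have been measured in a physicochemical assay for solubility, read by HPLC, measured as octanol-water partition, at pH 7.4; on this read-out higher numbers stand for higher solubility and lower numbers for lower solubility. Compound 2 `Clc1ccc2c(NCCCCCCCCNc3nccc(Cl)n3)ccnc2c1` gives 2910 nM, the highest of the three numbers. Compound 1 `Clc1ccc2c(NCCCOc3nccc(Cl)n3)ccnc2c1` gives 2190 nM, which lies within the usual scatter of the number for compound 2, so the two cannot be ranked against each other. Compound 3 `Clc1ccc2c(NCCCNc3ccnc(Cl)n3)ccnc2c1` gives 1010 nM, a gap to compound 2 that does lie beyond the scatter, so on these numbers compound 3 stands clearly lower than compound 2.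

Within the data shown here, no two of the measured compounds differ in a single place, so no measured step is available to lean on. Compound 4 `Clc1ccc2c(NCCCCCCCNc3nccc(Cl)n3)ccnc2c1` differs from compound 2 in one place only: (4-chloropyrimidin-2-yl)amino in place of ((4-chloropyrimidin-2-yl)amino)methyl on a saturated chain carbon, seven bonds along the chain from a nitrogen on an aromatic ring. The two compounds keep the same rings, the same hydrogen-bond donors and acceptors, and the same absence of charge; only the saturated chain between the two aromatic nitrogens is affected.

With nothing measured to show how this chain responds, the expectation is that the step of a 1.1-fold lower number from compound 2 to compound 4 (0.05 log units; within the scatter) stays within the scatter, with no clear direction. Compound 4 is therefore estimated at 2600 nM, with a range from 1300 nM to 5200 nM.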

Compound 4, solubility: 1920 nM
Beside the measured number, compound 4's estimate is 1.4-fold (0.13 log units) above it, within the range that was stated.
By their numbers in this assay, from the lowest: compounds 3, 4, 1 and 2 (each within the scatter of the next, the first and the last beyond it).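

Among these compounds, this is the first pair in the set that differs in a single place, so it gives the first direct look at how the number in this assay responds to a change in the length of the saturated chain. Putting (4-chloropyrimidin-2-yl)amino in place of ((4-chloropyrimidin-2-yl)amino)methyl, on a saturated chain carbon seven bonds along the chain from a nitrogen on an aromatic ring, gives a 1.5-fold lower number from compound 2 to compound 4 (0.18 log units; within the scatter), so this one shortening of the chain cannot be told apart from the noise of repeat measurements, and the two compounds cannot be ranked against each other. No measured property is available here that would explain the outcome or tie it to any feature of the chain.

A single step at one chain length says nothing about how far this flat response extends, and a chain longer than that of compound 2 could still behave differently. Equally open is what would happen with a different group on this saturated chain carbon, such as a carboxylic acid or a tertiary amine, since every chain shown here carries only carbon and hydrogen at this place.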